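The compounds below may be only part of what the source reports. "The series", "measured", "known", "first", "only" and "open" are said of these compounds alone.

Measured so far:
compound 1, `Cc1cccc(-c2noc(C(C)NC(=O)c3cc(C4CC4)nn3C)n2)c1`, 1880 nM
compound 2, `C[C@H](NC(=O)c1cc(C(F)(F)F)nn1C)c1nc(-c2cnn(C)c2)no1`, 2640 nM
compound 3, `C[C@H](NC(=O)c1cc(C(F)(F)F)nn1C)c1nc(-c2ccnc(N3CCCC3)c2)no1`, 573 nM

The three measured compounds were tested in an assay on T-REx-293 cells for inhibition of potassium channel subfamily T member 1 (Homo sapiens), read by patch clamp; a higher number here means a weaker inhibitor, a lower number a stronger inhibitor. Compound 3 stands at the lowest number of the three, and both its neighbours lie beyond the scatter: compound 1 gives 1880 nM and compound 2 gives 2640 nM in this assay, so compound 3 is the strongest inhibitor among those measured.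

Compound 4, `COC(C)(C)c1cc(-c2noc([C@H](C)NC(=O)c3cc(C(F)(F)F)nn3C)n2)ccn1`, has not yet been measured in this assay. It differs from compound 3 in one place: 1-methoxy-1-methylethyl in place of pyrrolidin-1-yl on an aromatic carbon. Among the compounds with values here, no step between measured compounds involves this kind of exchange, so nothing in the measured set says how large such a change should be. Both groups have the same count of heavy atoms and the same count of hydrogen-bond acceptors, and the shared core is unchanged, so a step in either direction beyond the scatter is possible, but the expectation is for a modest step at most, with a slight lean toward a weaker inhibitor. The expected step from compound 3 to compound 4 is a 1.6-fold higher number from compound 3 to compound 4 (0.20 log units; within the scatter). Compound 4 is therefore estimated at 900 nM in this assay, within a range from 300 nM to 2700 nM.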

Compound 4, half-maximal inhibitory concentration: 6280 nM
Compound 4: middle estimate off by 7.0-fold (0.84 log units), on the low side, and the stated range ends below it.
By their numbers in this assay, from the lowest: compound 3; then compounds 1 and 2 (each within the scatter of the next); then compound 4.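

In this assay, within the data shown here, exchanging pyrrolidin-1-yl for 1-methoxy-1-methylethyl on an aromatic carbon next to the ring nitrogen gives an 11-fold higher number from compound 3 to compound 4 (1.04 log units; beyond the scatter), and this is the first step in the set to isolate this position. The two groups match in heavy atoms, hydrogen-bond donors, hydrogen-bond acceptors and net charge, yet the step is large, so for this pair those matching counts do not mean matching values. The groups do differ in that pyrrolidin-1-yl has a five-membered ring and a nitrogen, whereas 1-methoxy-1-methylethyl has no ring and an oxygen, but no accompanying measurement bears on what lies behind the step.

The compounds shown do not separate the loss of the ring from the exchange of nitrogen for oxygen, and it stays open whether dimethylamino, an open-chain amine, or cyclopentyl, a ring without nitrogen, would stand nearer compound 3 or compound 4. On these data alone, it also stays open whether a step of this size would recur at this position if the trifluoromethyl on the shared core were replaced by a chlorine or a methyl group.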